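This account rests on a few compounds, and the source may have more. Where it says the series, first, only, none or still open, it means among the compounds named here.

Compound 1 `COc1ccc(NCN2C(=O)c3cccc(N)c3C2=O)cc1` carries an amino group on its ring system. In an assay on isolated protein for inhibition of ribosomal protein S6 kinase alpha-2 (Homo sapiens), read by fluorescence, with a stated time of 20 min, tested at 10 uM (a lower number here means less inhibition, a higher number more inhibition at the concentration tested (going by the name of the read-out)), compound 1 gives 95.6%. Compound 2 `COc1ccc(NCN2C(=O)c3ccc(N)cc3C2=O)cc1` is built from the same atoms joined differently; the difference between the two cores is not broken down here. In this assay compound 2 gives 109%, a number beyond the scatter above that of compound 1. Compound 3 `COc1ccc(NCN2C(=O)c3cccc(NC(=O)c4ccccc4)c3C2=O)cc1` differs from compound 1 by benzoyl in place of hydrogen on a nitrogen on an aromatic ring, and in this assay compound 3 gives 99.5%, so the step of a number 3.9 percentage points higher from compound 1 to compound 3 (within the scatter) is small. Compound 4 `COc1ccc(NCN2C(=O)c3ccc(NC(=O)c4ccccc4)cc3C2=O)cc1` differs from compound 2 by benzoyl in place of hydrogen on a nitrogen on an aromatic ring, the same change made on the core of compound 2. The step from compound 2 to compound 4 is expected to be about a number 4 percentage points lower from compound 2 to compound 4 (within the scatter), because the same change gave a number 3.9 percentage points higher from compound 1 to compound 3 (within the scatter). Compound 4 is therefore estimated at 105%, expected between 90% and 118%.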

Compound 4, a percentage reported as inhibition, at one concentration (the size of the read-out at that concentration, not a potency): 82%
For compound 4 the middle estimate is 23 percentage points above the measured one; measured number outside the range, below it.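

In this assay, the change from amino to benzamido gives a number 27 percentage points lower from compound 2 to compound 4 (beyond the scatter), so on the core of compound 2 this change lowers the inhibition seen at the concentration tested. The change therefore does not carry over unchanged from one core to the other in this series: the same change on two cores in this assay, a number 3.9 percentage points higher (within the scatter) from compound 1 to compound 3 and a number 27 percentage points lower (beyond the scatter) from compound 2 to compound 4, 30.9 percentage points apart, beyond the scatter of two such steps. This rests on one pair of compounds per core, so it shows that the outcome depends on the core here, but not why it does, nor whether other groups would behave the same way.

The compounds shown leave open whether a smaller acyl group such as acetyl, placed on the same nitrogen, would also differ between the two cores. They also leave open how a carboxylic acid on the benzoyl ring would behave.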